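Ethyl on the ring nitrogen of compound 1

The source may report more compounds than this note shows. Statements on the series, on what has been measured and on what is new or still open speak of the compounds shown alone.

Measured in a functional assay on NCI-H1650 cells (Homo sapiens) for cytotoxicity, read by MTT assay, with a stated time of 72 h (a higher number here means a weaker inhibitor, a lower number a stronger inhibitor), so far:
compound 1 `COc1ccc(/C=C2\CNC/C(=C\c3ccc(OC)c(OC)c3)C2=O)cc1OC` gives 16700 nM
compound 2 `COc1cc(/C=C2\CNC/C(=C\c3cc(OC)c(OC)c(OC)c3)C2=O)cc(OC)c1OC` gives 4200 nM
compound 3 `CCN1C/C(=C\c2cc(OC)c(OC)c(OC)c2)C(=O)/C(=C/c2cc(OC)c(OC)c(OC)c2)C1` gives 8200 nM

Compound 1 at 16700 nM has the highest number of the three and is thus the weakest inhibitor among them. Compound 3 lies nearest to it and compound 2 furthest away. The unmeasured compound 4 `CCN1C/C(=C\c2ccc(OC)c(OC)c2)C(=O)/C(=C/c2ccc(OC)c(OC)c2)C1` differs from compound 1 by ethyl in place of hydrogen on an amine nitrogen in a ring and by nothing else.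

Going by the values given here, only one measured step makes the same change. It is a 2.0-fold higher number from compound 2 to compound 3 (0.29 log units; within the scatter) and it belongs to a different pair of compounds, so the evidence is thin. Since that step did not leave the scatter, no step beyond the scatter is expected in this assay here, though a slight rise in the number would match its direction. The estimated change is a 1.2-fold higher number from compound 1 to compound 4 (0.08 log units; within the scatter) as expected from that single precedent. For compound 4 the estimated value is 20000 nM with an expected range from 9000 nM to 40000 nM in this assay.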

Compound 4, half-maximal inhibitory concentration: 12000 nM
Compound 4: the middle estimate sits 1.7-fold (0.22 log units) above what was measured; low and high end bracket the measured number.
By their numbers in this assay, from the lowest: compounds 2, 3, 4 and 1 (each within the scatter of the next, the first and the last beyond it).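

In this assay the change now has a second reading on a different core, a 1.4-fold lower number from compound 1 to compound 4 (0.14 log units; within the scatter) and so it again stays small. On neither core does ethyl in place of hydrogen on the amine nitrogen in the ring take the number beyond the scatter, so in these two pairs the position accepts ethyl without a clear gain or loss. The two readings do not share a direction, however, and the gap between them is larger than the scatter allows, so the same change does not carry one fixed size across the two cores: (the same change on two cores in this assay, a 2.0-fold higher number (0.29 log units; within the scatter) from compound 2 to compound 3 and a 1.4-fold lower number (0.14 log units; within the scatter) from compound 1 to compound 4, 2.7-fold (0.43 log units) apart, beyond the scatter of two such steps).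

The compounds shown leave open whether a longer chain, a benzyl group or an acetyl group on this nitrogen would move the number beyond the scatter in this assay on either core. They also leave open whether the gap between the two readings would recur with such groups.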